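Amide swap on the shared core: solubility outlook

This account rests on a few compounds, and the source may have more. Where it says the series, first, only, none or still open, it means among the compounds named here.

Compound 1 `Cn1cc(CNS(=O)(=O)c2ccccc2Nc2cc(-c3ccc4ccn(C)c4c3)c3nccnc3c2)cn1` and compound 2 `CC(=O)N1CCC(NC(=O)c2ccncc2Nc2cc(-c3ccc4ccn(C)c4c3)c3nccnc3c2)CC1` share a core but differ widely in a physicochemical assay for solubility, read by spectrophotometry, measured as kinetic solubility, at pH 8, tested at 500 uM; on this read-out higher numbers stand for higher solubility and lower numbers for lower solubility: compound 1 gives 2 ug/mL, while compound 2 gives 213 ug/mL, the highest of the two numbers and a gap beyond the scatter. Compound 3 `CN1CCC(N(C)C(=O)c2ccncc2Nc2cc(-c3ccc4ccn(C)c4c3)c3nccnc3c2)C1` is not yet measured in this assay; it differs from compound 2 by methyl(1-methylpyrrolidin-3-yl)amino in place of (1-acetylpiperidin-4-yl)amino on a carbonyl carbon. Within the data shown here, no measured pair covers this change. For compound 3 the step of a 1.1-fold lower number from compound 2 to compound 3 (0.05 log units; within the scatter) is expected to stay within the scatter, given that compound 2 already gives 213 ug/mL. Compound 3 is thus estimated at 190 ug/mL, with a range of 100 ug/mL to 240 ug/mL.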

Compound 3, solubility: 245 ug/mL
Compound 3: the middle estimate sits 1.3-fold (0.11 log units) below what was measured, and the stated range ends below it.
By their numbers in this assay, from the lowest: compound 1; then compounds 2 and 3 (each within the scatter of the next).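

The step of a 1.2-fold higher number from compound 2 to compound 3 (0.06 log units; within the scatter) in this assay shows that methyl(1-methylpyrrolidin-3-yl)amino can replace (1-acetylpiperidin-4-yl)amino on this carbonyl carbon without a shift beyond the scatter. The ring size, the acetyl group and the amide hydrogen all change together in this single pair, so their separate contributions cannot be read. No evidence on the cause of this outcome is available. Still open, going by these compounds, is whether a morpholine or a carboxylic acid-bearing chain on the same carbonyl carbon would keep the read-out at this level.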